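A few compounds are considered here, and "the series" means these few. Any claim that something is new, unique, unknown or untested is made for them only; others in the source may bear on it.

Compound 1 `Cc1c(C)c2c(c(C)c1OC(=O)CCC(=O)O)CCC(C)(C(=O)NC1CC(C)(C)N([O])C(C)(C)C1)O2`: in a functional assay on CEM13 cells (Homo sapiens) for cytotoxicity, read by MTT assay, with a stated time of 72 h (a lower number here means a stronger inhibitor, a higher number a weaker inhibitor), compound 1 gives > 300000 nM, which is a limit of the assay rather than a number.
Compound 2 `Cc1c(C)c2c(c(C)c1O)CCC(C)(C(=O)NC1CC(C)(C)N([O])C(C)(C)C1)O2`: in this assay compound 2 gives > 300000 nM, again only a limit.
Compound 3 `Cc1c(C)c2c(c(C)c1OC(=O)CCC(=O)O)CCC(C)(C(=O)NCC1CC(C)(C)N([O])C1(C)C)O2`: in this assay compound 3 gives > 300000 nM, also a limit.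

All three measured values sit at one and the same point, the limit (the limit of > 300000 nM in this assay, at which 3 of the 3 values shown sit). Compound 2 differs from compound 1 by hydrogen in place of (2-carboxyethyl)carbonyl on an oxygen on an aromatic ring. The step that the two limits leave unreadable from compound 1 to compound 2 has no readable size, since both of its ends are limits. Compound 3 differs from compound 1 by a group of 11 heavy atoms (9 carbon, 1 nitrogen, 1 oxygen; one five-membered non-aromatic ring with 1 hetero atom) in place of a group of 11 heavy atoms (9 carbon, 1 nitrogen, 1 oxygen; one six-membered non-aromatic ring with 1 hetero atom), on an amide-type nitrogen, a rearrangement of the same atoms into a different ring. The step that the two limits leave unreadable from compound 1 to compound 3 is likewise not readable, both ends again being limits.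

Compound 4 `Cc1c(C)c2c(c(C)c1O)CCC(C)(C(=O)NCC1CC(C)(C)N([O])C1(C)C)O2` has not yet been measured. It stands to compound 3 exactly as compound 2 stands to compound 1: the change is hydrogen in place of (2-carboxyethyl)carbonyl on an oxygen on an aromatic ring, the same change at the same kind of place, with the place described in identical words for both pairs. The step from compound 3 to compound 4 is expected to be a step that the limit leaves unreadable from compound 3 to compound 4, which rests on the step that the two limits leave unreadable from compound 1 to compound 2 and on the fact that every measured value sits at the limit of > 300000 nM in this assay, at which 3 of the 3 values shown sit. Compound 4 is therefore expected to give about 600000 nM in this assay, with the range 250000 nM to 3000000 nM, and most likely the assay will again report only a limit for compound 4.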

Compound 4, half-maximal inhibitory concentration: > 300000 nM
Compound 4 ended at the assay's limit; the forecaster's own chance of this, stated with the estimate: 90%; the middle value lies beyond the limit too.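

In this assay, compound 3 and compound 4 both end at a limit rather than at a number, so the change from (2-carboxyethyl)carbonyl to hydrogen has no readable size between them: the limit of > 300000 nM in this assay, at which 4 of the 4 values shown sit. The compounds shown leave open whether this change, or the change of ring on the amide-type nitrogen, alters cytotoxicity at all, as none of them gives an actual number.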